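The source may hold more compounds than are shown below. What is called first, only, known or untested is meant among the compounds shown, and "the series" means these compounds.

In a functional assay on PANC-1 cells (Homo sapiens) for inhibition, read by XTT assay, with a stated time of 72 h (a higher number here means a weaker inhibitor, a lower number a stronger inhibitor), compound 1 `CCCCCCCC/C=C/CCCCCCCCOC[C@@H]1CCCN1C(=O)OC(C)(C)C` gives > 100000 nM, which is a limit of the assay and not a number. Going by the values given here, compound 2 `CC(C)(C)OC(=O)N1CCC[C@H]1COCCCCCCCC/C=C/c1ccc(-c2ccccc2)cc1` gives 90000 nM, the only actual number available so far, so it cannot yet be ranked against any other measured value. The next compound, compound 3 `CC(C)(C)OC(=O)N1CCC[C@H]1COCCCCCCCC/C=C/c1ccc(Oc2ccccc2)cc1`, keeps the rest of compound 2 and carries phenoxy in place of phenyl on an aromatic carbon, para to a large group (phenoxy in place of phenyl on an aromatic carbon).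

Among the compounds with values here, only one measured step bears on this change, and it is an indirect guide: an at least 1.1-fold lower number from compound 1 to compound 2 (0.04 log units; that floor lies within the scatter). That step replaced a whole chain end, yet it did not move the reading beyond the scatter. The swap in compound 3 is smaller, so no step beyond the scatter is expected in this assay, and no direction can be favoured with any confidence. The expected step is a 1.1-fold lower number from compound 2 to compound 3 (0.05 log units; within the scatter). Compound 3 is estimated at 80000 nM, with an expected range from 40000 nM to 100000 nM.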

Compound 3, half-maximal inhibitory concentration: 90000 nM
Estimate against measurement, compound 3: 1.1-fold (0.05 log units) below; low and high end bracket the measured number.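

Going by these compounds alone, the first comparison between two actual numbers shows no change at the digits printed from compound 2 to compound 3 (within the scatter) in this assay. Phenoxy, which brings an oxygen and a hydrogen-bond acceptor that phenyl lacks, can therefore take the place of phenyl on this aromatic carbon, para to a large group, without a reading that can be told apart from that of phenyl, so this exchange offers no gain in this assay. Compound 1 stands at a limit and not at a number, so the earlier step gave only a floor, and the reading for this series still has to be judged against that ceiling: the limit of > 100000 nM in this assay, at which 1 of the 3 values shown sits.

The compounds shown leave open whether any group at this aromatic carbon can move the reading clear of the scatter, for example an amine or a carboxylic acid in place of phenoxy. They also leave open whether changes elsewhere, such as a shorter chain or a free amine in place of the tert-butoxycarbonyl group on the shared core, would matter more than any change at this position.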